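Replacing the aromatic ketone of the chain by an aldehyde

A few compounds are considered here, and "the series" means these few. Any claim that something is new, unique, unknown or untested is made for them only; others in the source may bear on it.

In an assay on isolated protein for inhibition of Fatty-acid amide hydrolase 1 (Homo sapiens) (a higher number here means a weaker inhibitor, a lower number a stronger inhibitor), compound 1 `CCCCCCCC/C=C\CCCCCCC(=O)c1nc2cccnc2o1` gives 11 nM, and compound 2 `CCCCCCCC/C=C\CCCCCCC(=O)c1nc2ncccc2o1` gives 2.3 nM; the step between them is a 4.8-fold lower number from compound 1 to compound 2 (0.68 log units; beyond the scatter). Compound 3 `CCCCCCCC/C=C\CCCCCCC(=O)c1ccccn1` carries a (pyridin-2-yl)carbonyl in place of the bicyclic heteroaryl ketone of the other two. For compound 3 this assay reports only a limit, > 100000 nM. The measured steps that lead to it are large: an at least 9000-fold higher number from compound 1 to compound 3 (3.95 log units; beyond the scatter) and an at least 43000-fold higher number from compound 2 to compound 3 (4.63 log units; beyond the scatter). Compound 3 therefore stands at the weak end of the numbers shown, at the assay limit (the limit of > 100000 nM in this assay, at which 1 of the 3 values shown sits).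

Compound 4 `CCCCCCCC/C=C\CCCCCCCC=O` differs from compound 3 by formylmethyl in place of (pyridin-2-yl)carbonyl on a saturated chain carbon, six bonds along the chain from a double-bonded chain carbon. Within the data shown here, no measured step removes the aromatic group on the carbonyl carbon entirely, so the comparison rests on the two steps into compound 3, both of which show that the group on the carbonyl carbon decides whether any inhibition is seen at all. With the aromatic ring gone, no return toward the values of compound 1 or compound 2 is expected; the expected step is a number no higher from compound 3 to compound 4 (the limit leaves the size open), that is no movement beyond the scatter away from the limit. Compound 4 is estimated at 100000 nM, within 10000 nM to 300000 nM, with a strong chance that only a limit is reported again.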

Compound 4, inhibition constant: 190 nM
The estimate for compound 4 lay 530-fold (2.72 log units) above the measured number; the measured number lies below the stated range.
By their numbers in this assay, from the lowest: compound 2; then compound 1; then compound 4. At a limit, above all of these: compound 3.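

In this assay, the change to formylmethyl gives an at least 520-fold lower number from compound 3 to compound 4 (2.72 log units; beyond the scatter), so the (pyridin-2-yl)carbonyl group is not the minimum needed for a measurable number in this series. The first three compounds could be read as saying that only the larger aromatic groups of compound 1 and compound 2 gave measurable inhibition, with compound 3 showing what happened when that group was reduced to a single ring; compound 4 goes against that reading, since it has no ring at all and still gives a number. Compound 3 carries only a limit of the assay, so this step sets a minimum and does not give a true size: the limit of > 100000 nM in this assay, at which 1 of the 4 values shown sits.

The compounds shown do not tell whether the aldehyde itself matters, or whether a carboxylic acid, a primary alcohol or a trifluoromethyl ketone in its place would keep a number of this order. They also leave open whether a monocyclic aromatic group other than pyridin-2-yl, such as an oxazol-2-yl group, would sit at the limit with compound 3 or give a measurable number.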